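The source may report more compounds than this note shows. Statements on the series, on what has been measured and on what is new or still open speak of the compounds shown alone.

Measured in a functional assay on HeLa cells (Homo sapiens) for cytotoxicity, read by WST assay, with a stated time of 48 h; a lower number here means a stronger inhibitor, a higher number a weaker inhibitor:
- Compound 1 `COc1cc(C(c2ccc(O)c(OC)c2)[C@H](C)C(C)C)ccc1O`: 16000 nM
- Compound 2 `COC[C@H](C)[C@@H](C)C(c1ccc(O)c(OC)c1)c1ccc(O)c(OC)c1`: 77000 nM
- Compound 3 `COC[C@@H](C(C)C)C(c1ccc(O)c(OC)c1)c1ccc(O)c(OC)c1`: 69000 nM

Compound 1 holds the lowest number of the three, and both others lie beyond the scatter from it. Compound 4 `CCCCCCCC[C@H](C(C)C)C(c1ccc(O)c(OC)c1)c1ccc(O)c(OC)c1` differs from it by heptyl in place of hydrogen on a saturated chain carbon, three bonds along the chain from two aromatic carbons. For the measured compounds named here, two measured steps bear on this change, though only loosely: a 4.8-fold higher number from compound 1 to compound 2 (0.68 log units; beyond the scatter) and a 4.3-fold higher number from compound 1 to compound 3 (0.63 log units; beyond the scatter). Going by the values given here, each brings in methoxy, and no measured compound carries a heptyl. The two methoxy compounds themselves stand level: a 1.1-fold lower number from compound 2 to compound 3 (0.05 log units; within the scatter). As far as these compounds go, with only these modest steps as a guide, no step beyond the scatter is expected in this assay, and the direction stays open. For compound 4 the estimate is 13000 nM, with an expected range of 3500 nM to 50000 nM. The estimated change is a 1.2-fold lower number from compound 1 to compound 4 (0.09 log units; within the scatter).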

Compound 4, half-maximal inhibitory concentration: 3100 nM
Compound 4: middle estimate off by 4.2-fold (0.62 log units), on the high side; measured number below the stated range.
By their numbers in this assay, from the lowest: compound 4; then compound 1; then compounds 3 and 2 (each within the scatter of the next).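

In this assay, heptyl in place of hydrogen on this saturated chain carbon gives a 5.2-fold lower number from compound 1 to compound 4 (0.71 log units; beyond the scatter). The position therefore tolerates a long all-carbon chain, and the number falls, whereas the two earlier steps from compound 1, both bringing in methoxy, had raised it. No measurement given here explains this change.

For the compounds shown here, only one chain length stands at this place, so it remains open whether a shorter chain such as propyl or a longer chain such as decyl would move the number further. As far as these compounds go, it is also open whether an amine or a carboxylic acid at the chain end would keep the drop.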